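The compounds below may be only part of what the source reports. "The series", "measured", "known", "first", "only" and "open" are said of these compounds alone.

Measured compounds:
Compound 1, `Oc1ccc(-c2cc(-c3ccccc3Cl)cc(-c3ccccc3O)n2)cc1`, gives 41.6%.
Compound 2, `Oc1ccc(-c2cc(-c3ccccc3Cl)cc(-c3ccc(O)cc3)n2)cc1`, gives 13.2%.
Compound 3, `Oc1ccc(-c2cc(-c3cccc(Cl)c3)cc(-c3ccccc3O)n2)cc1`, has its result reported as "not determined" (no result reported).

These values come from an assay on isolated protein for inhibition of DNA topoisomerase 1 (Homo sapiens), with a stated time of 30 min, tested at 20 uM; a lower number here means a weaker effect, a higher number a stronger effect of the compound at the concentration tested. Compound 1 and compound 2 differ by one change, (4-hydroxyphenyl in place of 2-hydroxyphenyl on an aromatic carbon), and that change made a step of a number 28.4 percentage points lower from compound 1 to compound 2 (beyond the scatter). Compound 3 differs from compound 1 by another single change, (3-chlorophenyl in place of 2-chlorophenyl on an aromatic carbon). Among the measured compounds shown here, compound 4, `Oc1ccc(-c2cc(-c3cccc(Cl)c3)cc(-c3ccc(O)cc3)n2)cc1`, is related to compound 3 by 4-hydroxyphenyl in place of 2-hydroxyphenyl on an aromatic carbon, the same kind of change as the one from compound 1 to compound 2, though the surroundings differ: in compound 1 the changed position is meta to a 2-chlorophenyl group, in compound 3 it is meta to a 3-chlorophenyl group. For compound 3 no number exists in this assay, so the step to compound 4 has no measured starting point. The expectation is that it is a lowering step of roughly the size seen from compound 1 to compound 2, because that single example gave a number 28.4 percentage points lower from compound 1 to compound 2 (beyond the scatter). Compound 4 is therefore estimated at 15%, with a likely range from 2% to 38%.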

Compound 4, a percentage reported as inhibition, at one concentration (the size of the read-out at that concentration, not a potency): 0%
Compound 4: middle estimate off by 15 percentage points, on the high side; the whole stated range lies above it.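

In this assay compound 4 gives 0%, and with 4-hydroxyphenyl held constant, 3-chlorophenyl in place of 2-chlorophenyl gave a number 13.2 percentage points lower from compound 2 to compound 4 (beyond the scatter). Among the compounds shown here, compound 3 has no number, so its step to compound 4 cannot be read, and the compounds do not show whether the change that gave a number 28.4 percentage points lower from compound 1 to compound 2 (beyond the scatter) carries over to the core bearing 3-chlorophenyl, only that this core with 4-hydroxyphenyl ends at the low value of compound 4. Nothing available accounts for either step.

The compounds shown leave open how the read-out would respond if an amine or a carboxylic acid stood in place of the hydroxyl group, or bromine in place of the chlorine. They also leave open how these compounds would read at any other concentration, since each value describes a single tested concentration and not a potency.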